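The source may report more compounds than this note shows. Statements on the series, on what has been measured and on what is new or still open speak of the compounds shown alone.

In a functional assay on MCF7 cells (Homo sapiens) for antiproliferative activity, read by MTT assay, with a stated time of 72 h (a higher number here means a weaker inhibitor, a lower number a stronger inhibitor), compound 1 `CCN(CC)c1ccc(/C=N/NC(=O)c2cccc(S(=O)(=O)N3CCOCC3)c2)c(O)c1` gives 3520 nM, compound 2 `COc1ccc(/C=N/NC(=O)c2cccc(S(=O)(=O)N3CCOCC3)c2)c(O)c1` gives 5140 nM and compound 3 `CCOc1cccc(/C=N/NC(=O)c2cccc(S(=O)(=O)N3CCOCC3)c2)c1O` gives 19300 nM, the highest of the three numbers. Compound 4 `O=C(N/N=C/c1cc(Br)cc(Br)c1O)c1cccc(S(=O)(=O)N2CCOCC2)c1` has not yet been measured, and its difference from compound 3 is this: 3,5-dibromo-2-hydroxyphenyl in place of 3-ethoxy-2-hydroxyphenyl on a carbon with a double bond to nitrogen. The closest measured change, at the same place, is a 3.8-fold higher number from compound 2 to compound 3 (0.57 log units; beyond the scatter). The other measured change, a 1.5-fold higher number from compound 1 to compound 2 (0.16 log units; within the scatter), offers little guidance. A step of similar modest size is therefore expected, towards a lower number, since compound 3 stands at the top at 19300 nM. The expected step is a 2.8-fold lower number from compound 3 to compound 4 (0.44 log units; beyond the scatter). For compound 4 the estimated value is 7000 nM, with an expected range of 2200 nM to 22000 nM.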

Compound 4, half-maximal inhibitory concentration: 16000 nM
Compound 4: middle estimate off by 2.3-fold (0.36 log units), on the low side, and the stated range covers the measured number.
By their numbers in this assay, from the lowest: compounds 1 and 2 (each within the scatter of the next); then compounds 4 and 3 (each within the scatter of the next).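

In this assay the 3,5-dibromo-2-hydroxyphenyl and 3-ethoxy-2-hydroxyphenyl groups on this carbon cannot be told apart (a 1.2-fold lower number from compound 3 to compound 4 (0.08 log units; within the scatter)), although the two groups differ in their atoms. Both stand weaker than the 2-hydroxy-4-methoxyphenyl group, and for the dibromo group the step is a 3.1-fold higher number from compound 2 to compound 4 (0.49 log units; beyond the scatter). Nothing measured here explains this.

Going by these compounds, what remains open is whether a carboxylic acid or a nitrile on this ring would shift the number, and whether a phenyl without the hydroxy group would keep this activity.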